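This account rests on a few compounds, and the source may have more. Where it says the series, first, only, none or still open, it means among the compounds named here.

Measured so far:
compound 1, `COC(=O)C1=C(C)NC(C)=C(C(=O)OC(C)C)C1c1cnc(SC)n1Nc1ccccc1` — 6.35 nM
compound 2, `CCOC(=O)C1=C(C)NC(C)=C(C(=O)OCCOC)C1c1cnc(SC)n1Nc1ccccc1` — 2.91 nM

The two compounds share one core and differ only in the two ester groups hanging off it. In an assay on isolated protein (strain albino) for antagonist activity at Voltage-dependent L-type calcium channel subunit alpha-1C (Cavia porcellus) (a lower number here means a stronger inhibitor, a higher number a weaker inhibitor), compound 2 gives 2.91 nM, the lower of the two numbers recorded. In this assay compound 1 gives 6.35 nM, a higher number, and the gap between the two lies beyond the usual scatter, so compound 2 stands as the stronger inhibitor of the pair.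

Compound 3, `COCCOC(=O)C1=C(C)NC(C)=C(C(=O)OC(C)C)C1c1cnc(SC)n1Nc1ccccc1`, is still to be measured. Relative to compound 2 the change is methyl in place of hydrogen on a saturated chain carbon bound to an oxygen next to a carbonyl group and a saturated chain carbon; cut one bond further out, it reads as ethoxycarbonyl to isopropoxycarbonyl. Among the measured compounds shown here, no comparable single-point step between measured compounds is available, and the only guide is that both esters of the same general kind, seen in compound 1 and compound 2, fall within a narrow band in this assay. Compound 3 is therefore expected to stay close to compound 2, with a step from a 1.4-fold higher number from compound 2 to compound 3 (0.14 log units; within the scatter) that is small and, as estimated, not clearly beyond the scatter, perhaps leaning toward a slightly higher number. The estimate for compound 3 in this assay is 4 nM, within a range from 1.5 nM to 11 nM.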

Compound 3, half-maximal inhibitory concentration: 53.4 nM
Compound 3: the middle estimate sits 13-fold (1.13 log units) below what was measured, outside the stated range (above it).
By their numbers in this assay, from the lowest: compound 2; then compound 1; then compound 3.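

In this assay, the single added methyl that turns ethoxycarbonyl into isopropoxycarbonyl gives an 18-fold higher number from compound 2 to compound 3 (1.26 log units; beyond the scatter), so this ester position responds sharply to a change of one heavy atom, which the close numbers of the two earlier compounds gave no hint of. Isopropoxycarbonyl alone does not set the number, however: compound 1 carries that same group, and methoxymethyl in place of hydrogen on a saturated chain carbon bound to an oxygen next to a carbonyl group gives an 8.4-fold higher number from compound 1 to compound 3 (0.92 log units; beyond the scatter), so the ester on the other side also counts, and the two esters are not interchangeable in this series. Why either step is so large cannot be told, as nothing available on these compounds bears on the result.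

The compounds shown leave open whether the rise continues with a tert-butoxycarbonyl or a longer chain such as butoxycarbonyl at this position, or whether it is specific to the isopropyl branch. They also leave open how a carboxylic acid or an amine at the end of the ester chain would read in this assay, with either partner ester.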